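The compounds below may be only part of what the source reports. "The series", "measured", "known", "first", "only" and "open" are said of these compounds alone.

Measured so far:
compound 1 `CN(C(=O)NC(=O)c1cccc(C(F)(F)F)c1)c1nc(C(F)(F)F)c(C(=O)N/N=C/c2cccc(C(F)(F)F)c2)s1`: in a functional assay on HepG2 cells (Homo sapiens) for inhibition, read by MTT assay, with a stated time of 72 h (on this read-out higher numbers stand for weaker inhibition and lower numbers for stronger inhibition), compound 1 gives 5.79 ug/mL
compound 2 `CN(C(=O)NC(=O)c1ccc([N+](=O)[O-])cc1)c1nc(C(F)(F)F)c(C(=O)N/N=C/c2cccc(C(F)(F)F)c2)s1`: in this assay compound 2 gives 4.73 ug/mL

Compound 1 has the highest of the two numbers, with compound 2 nearest: a 1.2-fold lower number from compound 1 to compound 2 (0.09 log units; within the scatter). Those two values therefore show nothing beyond the scatter.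

Compound 3 `CN(C(=O)NC(=O)c1cccc(C(F)(F)F)c1)c1nc(C(F)(F)F)c(C(=O)N/N=C/c2cc(C(F)(F)F)cc(C(F)(F)F)c2)s1` is not yet measured. Its change from compound 1 is trifluoromethyl in place of hydrogen on an aromatic carbon, on the ring carried by the hydrazone rather than on the carbonyl side that was varied between compound 1 and compound 2. Within the data shown here, the only measured step, a 1.2-fold lower number from compound 1 to compound 2 (0.09 log units; within the scatter), concerns a different ring and was within the scatter, so it gives no direct guidance; no step bearing on a trifluoromethyl for hydrogen exchange on this ring exists. In this assay no step beyond the scatter is expected for compound 3, i.e. a 1.1-fold lower number from compound 1 to compound 3 (0.02 log units; within the scatter). Compound 3 is therefore estimated at 5.5 ug/mL, with a range of 2.5 ug/mL to 12 ug/mL.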

Compound 3, half-maximal inhibitory concentration: 5.38 ug/mL
Beside the measured number, compound 3's estimate is 1.0-fold (0.01 log units) above it; the measured number falls inside the stated range.
By their numbers in this assay, from the lowest: compounds 2, 3 and 1 (each within the scatter of the next).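

On the ring carried by the hydrazone, trifluoromethyl in place of hydrogen on an aromatic carbon, meta to a trifluoromethyl group, gives a 1.1-fold lower number from compound 1 to compound 3 (0.03 log units; within the scatter) in this assay. Among these compounds, this is the first reading on this ring, the earlier pair having varied only the carbonyl side, and it shows that this position takes the added group, with its 4 heavy atoms, without a step beyond the scatter. No measurement is at hand that would account for this result.

The compounds shown leave open whether an amine or a carboxylic acid at this place on the ring would also stay within the scatter. All three compounds carry at least one trifluoromethyl on this ring, so what the series does without that group cannot be read from them.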